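Trimming the Triazole Down to a Bare Amine

The compounds below may be only part of what the source reports. "The series", "measured", "known", "first", "only" and "open" are said of these compounds alone.

Compound 2 `NC(=O)c1cn(Cc2nnc(-c3cc(S(N)(=O)=O)c(SCc4ccccc4)cc3Cl)o2)nn1` sits at the second highest of the three numbers recorded in a functional assay on MCF7 cells (Homo sapiens) for cytotoxicity, read by MTT assay, with a stated time of 72 h (a higher number here means a weaker inhibitor, a lower number a stronger inhibitor), where compound 2 gives 78000 nM. Compound 1 `[N-]=[N+]=NCc1nnc(-c2cc(S(N)(=O)=O)c(SCc3ccccc3)cc2Cl)o1` gives 55000 nM, and compound 3 `COc1ccc(-c2cn(Cc3nnc(-c4cc(S(N)(=O)=O)c(SCc5ccccc5)cc4Cl)o3)nn2)cc1` gives 1500000 nM. The step of a 1.4-fold higher number from compound 1 to compound 2 (0.15 log units; within the scatter) is within the scatter, while the step of a 19-fold higher number from compound 2 to compound 3 (1.28 log units; beyond the scatter) is large. Compound 4 `NCc1nnc(-c2cc(S(N)(=O)=O)c(SCc3ccccc3)cc2Cl)o1` carries the change (amino in place of 4-carbamoyl-1H-1,2,3-triazol-1-yl on a saturated chain carbon bound to an aromatic carbon). Exchanging groups at this same saturated chain carbon from compound 1 to compound 2 barely moved the number, and the large step appeared only when the 4-methoxyphenyl entered in compound 3; the present change removes a ring rather than adding one. The step expected here is a 1.4-fold lower number from compound 2 to compound 4 (0.15 log units; within the scatter), no larger than the scatter. Compound 4 is estimated at 55000 nM, with a range from 20000 nM to 150000 nM.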

Compound 4, half-maximal inhibitory concentration: 135000 nM
The estimate for compound 4 lay 2.5-fold (0.39 log units) below the measured number; the range from low to high includes it.
By their numbers in this assay, from the lowest: compounds 1, 2 and 4 (each within the scatter of the next, the first and the last beyond it); then compound 3.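

In this assay, the 4-carbamoyl-1H-1,2,3-triazol-1-yl group on this saturated chain carbon gives way to amino with a 1.7-fold higher number from compound 2 to compound 4 (0.24 log units; within the scatter), so the number holds within the scatter with no ring left on this carbon. Set against azido, the same amino group gives a 2.5-fold higher number from compound 1 to compound 4 (0.39 log units; beyond the scatter), the first step at this carbon to pass the scatter, though only a modest one. Nothing on hand explains either step. 

On these data alone, whether a dimethylamino or an acetamido group on this carbon would keep the number in this range stays open. So does whether a plain phenyl in place of the 4-methoxyphenyl of compound 3 would bring the same large step.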